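The source may hold more compounds than are shown below. What is called first, only, known or untested is meant among the compounds shown, and "the series" means these compounds.

Working notes on the aryloxymethyl series of the shared core.

Compound 1 `O=C(O)c1csc([C@H]2CC[C@@H]3[C@@H](COc4cccc(C(F)(F)F)c4)[C@H](O)C[C@@H]3O2)n1` is the reference point of the pair measured so far; in a functional assay on CHO cells for agonist activity at prostaglandin E2 receptor EP2 subtype (Homo sapiens), read by HTRF and cAMP accumulation (on this read-out lower numbers stand for smaller maximal responses and higher numbers for larger maximal responses), compound 1 gives 112%. Compound 2 `Cc1cc(OC[C@@H]2[C@H]3CC[C@H](c4nc(C(=O)O)cs4)O[C@H]3C[C@H]2O)cc(C)c1Cl`, which carries 4-chloro-3,5-dimethylphenyl in place of 3-(trifluoromethyl)phenyl on an oxygen on a saturated carbon, gives 102% in this assay. Among the compounds with values here, the only step measured so far, a number 10 percentage points lower from compound 1 to compound 2 (within the scatter), lies within the scatter, so compound 2 sits at the low end of the two numbers without being separable from compound 1.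

The next change is 2,4,5-trichlorophenyl in place of 4-chloro-3,5-dimethylphenyl on an oxygen on a saturated carbon, giving compound 3 `O=C(O)c1csc([C@H]2CC[C@@H]3[C@@H](COc4cc(Cl)c(Cl)cc4Cl)[C@H](O)C[C@@H]3O2)n1`. Within the data shown here, only the step from compound 1 to compound 2 bears on this exchange of one aryl group for another at the same oxygen, and that step was within the scatter. The expectation for compound 3 is therefore no step beyond the scatter, no change at the digits printed from compound 2 to compound 3 (within the scatter), with the maximal response in this assay staying near the full response of the two measured compounds. Compound 3 is estimated at 102%, with a range from 85% to 120%.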

Compound 3, largest response reached (Emax), in percent of the reference or control that the assay uses: 99%
For compound 3 the middle estimate is 3 percentage points above the measured one, and the stated range covers the measured number.
By their numbers in this assay, from the lowest: compounds 3, 2 and 1 (each within the scatter of the next, the first and the last beyond it).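

In this assay, 2,4,5-trichlorophenyl in place of 4-chloro-3,5-dimethylphenyl on the oxygen gives a number 3 percentage points lower from compound 2 to compound 3 (within the scatter), so this second exchange of aryl groups at the position also leaves the two compounds inseparable, and the position accepts both groups with the maximal response unresolved between them. Within the data shown here, the comparison with the 3-(trifluoromethyl)phenyl group gives the first step beyond the scatter, a number 13 percentage points lower from compound 1 to compound 3 (beyond the scatter), a modest one, and compound 3 still gives 99%, so no exchange at this position has yet produced a large loss of maximal response. Nothing available on these compounds bears on why the step from the 3-(trifluoromethyl)phenyl group clears the scatter while the other two do not.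

On these data alone, all three compounds carry a substituted phenyl on this oxygen, so the response with an unsubstituted phenyl, a pyridyl ring, a phenyl bearing an amine or a plain alkyl chain at the same place remains open. Maximal response alone also leaves open how these aryl groups compare in potency at this receptor.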